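Cytotoxicity notes on amide series: pyridyl to hydroxyphenyl

The source may report more compounds than this note shows. Statements on the series, on what has been measured and on what is new or still open speak of the compounds shown alone.

Compound 1 `COc1ccc(-c2noc(NC(=O)c3ccc(F)cc3)c2C)cc1` and compound 2 `COc1ccc(-c2cnc(NC(=O)c3cccnc3)n2C)cc1` have both been run in a toxicity assay on THP-1 cells (Homo sapiens) for inhibition; on this read-out lower numbers stand for higher toxicity in this test and higher numbers for lower toxicity in this test. In this assay compound 1 gives > 100000 nM, which is a limit of the assay and not a number. In this assay compound 2 gives > 100000 nM, again a limit rather than a measured number. Where compound 2 stands is therefore known only as a limit; the two values shown both sit at the limit of > 100000 nM in this assay, at which 2 of the 2 values shown sit. Among the compounds with values here, no step between measured compounds exists here, so the pair compound 1 and compound 2 shows only that each reaches the limit.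

Compound 3 `COc1ccc(-c2cnc(NC(=O)c3ccc(O)cc3)n2C)cc1` is still to be measured in this assay. It differs from compound 2 by 4-hydroxyphenyl in place of pyridin-3-yl on a carbonyl carbon, the change sitting on a carbonyl carbon whose other neighbour is an amide-type nitrogen.

With both values at the limit, no step beyond the scatter is expected from compound 2 to compound 3, and the step of a number no higher from compound 2 to compound 3 (the limit leaves the size open) is the expected outcome. Compound 3 is therefore expected to give about 100000 nM in this assay, within a range from 40000 nM to 300000 nM, most likely again reported as a limit.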

Compound 3, half-maximal cytotoxic concentration: > 100000 nM
Compound 3: a limit, no number; the forecaster's own chance of this, stated with the estimate: 80%; the middle value sits exactly at the limit.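

In this assay compound 3 gives > 100000 nM as a limit, not a number. No step can be read from compound 2 to compound 3, since both stand only as limits: the limit of > 100000 nM in this assay, at which 3 of the 3 values shown sit. The compounds shown leave open where the actual half-maximal cytotoxic concentration of each lies, and whether any change in this series would bring it within range.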